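Pyrrolidine Amide Swap in a Chk2 Series

The source may hold more compounds than are shown below. What is called first, only, known or untested is meant among the compounds shown, and "the series" means these compounds.

Compound 1, `CN(CCCn1ccnc1)C(=O)[C@@H]1CCCN1c1nccc(Nc2ccccc2)n1`, gives 5%.
Compound 2, `COC[C@@H]1CCCN1C(=O)C1CCCN1c1cc(Nc2cccc(Br)c2)ncn1`, gives 3%.

Both measured compounds were tested in an assay on isolated protein for inhibition of serine/threonine-protein kinase Chk2 (Homo sapiens), read by HTRF, tested at 10 uM; a lower number here means less inhibition, a higher number more inhibition at the concentration tested (going by the name of the read-out). Among the measured compounds shown here, on these numbers, compound 1 and compound 2 cannot be told apart: the gap between them lies within the usual scatter of repeated measurements, so neither shows inhibition that stands out at the concentration tested, and no step between them can be claimed.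

Compound 3, `COC[C@@H]1CCCN1C(=O)[C@@H]1CCCN1c1nccc(Nc2ccccc2)n1`, has not yet been measured in this assay. It differs from compound 1 in one place: 2-(methoxymethyl)pyrrolidin-1-yl in place of (3-(1H-imidazol-1-yl)propyl)(methyl)amino on a carbonyl carbon. Compound 2 already carries the 2-(methoxymethyl)pyrrolidin-1-yl group on a carbonyl carbon, and it gives a low number in this assay, so the change is not expected to move the read-out beyond the scatter in either direction.

Compound 3 is therefore expected to give 5%, with a range from -5% to 15%. The step from compound 1 to compound 3 that this estimate means, no change at the digits printed from compound 1 to compound 3 (within the scatter), is expected to be no larger than the scatter.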

Compound 3, a percentage reported as inhibition, at one concentration (the size of the read-out at that concentration, not a potency): 3%
Estimate against measurement, compound 3: 2 percentage points above, within the range that was stated.
By their numbers in this assay, from the lowest: compounds 2, 3 and 1 (each within the scatter of the next).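

In this assay, putting 2-(methoxymethyl)pyrrolidin-1-yl in place of (3-(1H-imidazol-1-yl)propyl)(methyl)amino on a carbonyl carbon comes with a number 2 percentage points lower from compound 1 to compound 3 (within the scatter), and this is the only pair shown that differs in one place. It shows that, on the core of compound 1, exchanging a group with a five-membered aromatic ring for one with a five-membered non-aromatic ring and a defined stereocentre leaves the read-out within the scatter, so neither group can be ranked above the other at this place. No measurement shown bears on why the read-out stays where it does.

On these data alone, since both groups sit at the low end of the read-out, it remains open whether any other group on this carbonyl carbon, such as a small dimethylamino group, a piperazine or a longer chain ending in a primary amine, would give a number beyond the scatter. As far as these compounds go, it also remains open whether the 2-(methoxymethyl)pyrrolidin-1-yl group would behave the same way with other substituents on the phenyl ring of compound 3, as compound 2 differs from compound 3 in more than one place and cannot settle this.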